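Ring stereochemistry in the phenylcyclohexyl amine series

The source may hold more compounds than are shown below. What is called first, only, known or untested is meant among the compounds shown, and "the series" means these compounds.

Compound 3 `c1ccc(CNCC[C@H]2CCC[C@H](c3ccccc3)C2)cc1` gives 46 nM in an assay on membranes from liver for displacement of a labelled ligand from Sigma intracellular receptor 2 (Rattus norvegicus), read by scintillation counting, with a stated time of 120 min (a higher number here means a weaker inhibitor, a lower number a stronger inhibitor), the lowest of the two single numbers in the set. Compound 2 `CN(C)CCC1CCCC(c2ccccc2)C1`, drawn without configuration, gives 115 nM in this assay, a gap to compound 3 that lies beyond the usual scatter. Compound 1 `c1ccc(CNCC[C@@H]2CCC[C@@H](c3ccccc3)C2)cc1` has two entries, 268 nM; 57 nM (2 entries), so its figure is not settled; compound 1 and compound 3 are related by the fact that compounds 1 and 3 differ only in the configuration as drawn, and one entry of compound 1 sits close to compound 3 (the several entries of compound 1 in this assay, 268 nM; 57 nM (2 entries)). Compound 4 `c1ccc(CNCC[C@H]2CCC[C@@H](c3ccccc3)C2)cc1` is not yet measured; it differs from compound 3 thus: the two compounds have the same atoms and bonds and differ only in configuration as drawn: 1 of 2 stereo elements differ; a stereocentre at a saturated ring carbon is drawn S in compound 3 and R in compound 4. Inversion of a single ring centre has no measured counterpart here, so the direction is open; a step of modest size, or none beyond the scatter, is expected. Compound 4 is estimated at 100 nM (range 30 nM to 400 nM). The expected step is a 2.2-fold higher number from compound 3 to compound 4 (0.34 log units; beyond the scatter).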

Compound 4, inhibition constant: 47 nM
Estimate against measurement, compound 4: 2.1-fold (0.33 log units) above; low and high end bracket the measured number.
By their numbers in this assay, from the lowest: compounds 3 and 4 (each within the scatter of the next); then compound 2.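

Inverting this one saturated ring carbon gives a 1.0-fold higher number from compound 3 to compound 4 (0.01 log units; within the scatter) in this assay, the first single-centre change in the series that can be read. With the other stereo element held as drawn, the configuration at this ring carbon leaves the number within the scatter.

On these data alone, whether the other centre matters stays open, since compound 1, the remaining stereoisomer, has no settled figure: the several entries of compound 1 in this assay, 268 nM; 57 nM (2 entries) Also open is whether this insensitivity to configuration holds with a longer chain to the amine or a hydroxyl on the phenyl ring.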